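The source may report more compounds than this note shows. Statements on the series, on what has been measured and on what is new or still open speak of the compounds shown alone.

Measured so far:
Compound 1 `Fc1ccc(C2CC(c3ccccc3)=NN2c2ccc(-c3ccccc3)nn2)cc1` — in an ADME assay on HEK293 cells (Homo sapiens) for cytotoxicity, read by MTT assay, with a stated time of 24 h (on this read-out lower numbers stand for stronger inhibition and higher numbers for weaker inhibition), compound 1 gives > 300000 nM, a limit of the assay rather than a number.
Compound 2 `Clc1ccc(C2=NN(c3ccc(-c4ccccc4)nn3)C(c3ccccc3)C2)cc1` — in this assay compound 2 gives > 300000 nM, also a limit.
Compound 3 `Clc1ccc(C2=NN(c3ccc(-c4ccccc4)nn3)C(c3ccc(Cl)cc3)C2)cc1` — in this assay compound 3 gives > 300000 nM, again a limit.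

Compound 3 thus stands at a limit, not at a number, and the two other values shown beside it are limits as well, as summed up in the limit of > 300000 nM in this assay, at which 3 of the 3 values shown sit. Going by the values given here, the only measured step reads a step that the two limits leave unreadable from compound 2 to compound 3, so its size cannot be read.

Compound 4 `Fc1ccc(C2CC(c3ccc(Cl)cc3)=NN2c2ccc(-c3ccccc3)nn2)cc1` differs from compound 3 by fluoro in place of chloro on an aromatic carbon. No measured step bears on this change with a readable size; the one step shown is unreadable because of the limit of > 300000 nM in this assay, at which 3 of the 3 values shown sit. Compound 4 is therefore expected to sit at the same limit as its neighbours, and the expected step is a number no higher from compound 3 to compound 4 (the limit leaves the size open), nothing beyond the scatter. The estimate for compound 4 in this assay is 300000 nM, with a range from 100000 nM to 1000000 nM, and most likely the assay will again report only a limit.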

Compound 4, half-maximal inhibitory concentration: > 300000 nM
Compound 4: only a limit was reported; the forecaster's own chance of this, stated with the estimate: 85%; the middle value sits exactly at the limit.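

In this assay compound 4 gives > 300000 nM, a limit and not a number. Going by these compounds alone, no step from compound 1, compound 2 or compound 3 to compound 4 can be read: the limit of > 300000 nM in this assay, at which 4 of the 4 values shown sit. The compounds shown leave open what size the exchanges among hydrogen, chloro and fluoro have in this assay.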